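Removing ((dichloromethyl)carbonyl)amino from compound 3

A few compounds are considered here, and "the series" means these few. Any claim that something is new, unique, unknown or untested is made for them only; others in the source may bear on it.

In a functional assay on NCI-H460 cells (Homo sapiens) for cytotoxicity, read by MTT assay, with a stated time of 68 h (on this read-out higher numbers stand for weaker inhibition and lower numbers for stronger inhibition), compound 1 `O=C(Nc1cccc(-c2cccc(F)c2)c1)C(Cl)Cl` reads > 50000 nM, which is a limit of the assay. Compound 3 `O=C(Nc1cccc(-c2cccc(NC(=O)C(Cl)Cl)c2)c1)C(Cl)Cl` reads > 50000 nM, which is also a limit and gives no number for this compound. For the measured compounds named here, compound 2 `COc1cccc(-c2cccc(NC(=O)C(Cl)Cl)c2)c1` gives 33800 nM, the only numerical value in the set. The upper end of this assay is crowded: the limit of > 50000 nM in this assay, at which 2 of the 3 values shown sit.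

Compound 4 `O=C(Nc1cccc(-c2ccccc2)c1)C(Cl)Cl` differs from compound 3 by hydrogen in place of ((dichloromethyl)carbonyl)amino on an aromatic carbon, with hydrogen in place of ((dichloromethyl)carbonyl)amino on an aromatic carbon.

Three measured steps exchange groups at this same place: an at least 1.4-fold lower number from compound 1 to compound 2 (0.17 log units; that floor lies within the scatter), a step that the two limits leave unreadable from compound 1 to compound 3 and an at least 1.4-fold higher number from compound 2 to compound 3 (0.17 log units; that floor lies within the scatter). From the compounds shown here alone, none of them can be read as a change beyond the scatter, so no step beyond the scatter is expected here, and the direction remains open. The expected step, measured against a limit, is an at least 1.1-fold lower number from compound 3 to compound 4 (0.04 log units; that floor lies within the scatter).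

For compound 4 the estimated value is 45000 nM, with an expected range of 22000 nM to 90000 nM.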

Compound 4, half-maximal inhibitory concentration: 20200 nM
Compound 4: middle estimate off by 2.2-fold (0.35 log units), on the high side; the measured number lies below the stated range.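

With hydrogen on this aromatic carbon, meta to a large group, the position gives readable steps beyond the scatter, which no earlier exchange there did: an at least 2.4-fold lower number from compound 3 to compound 4 (0.39 log units; beyond the scatter) and an at least 2.4-fold lower number from compound 1 to compound 4 (0.39 log units; beyond the scatter). Hydrogen and methoxy, however, are not separated at this place: a 1.7-fold lower number from compound 2 to compound 4 (0.22 log units; within the scatter). The two steps beyond the scatter are floors and not full sizes, because both start from a compound at the assay limit: the limit of > 50000 nM in this assay, at which 2 of the 4 values shown sit.

From the compounds shown here alone, how large the steps from fluoro and from ((dichloromethyl)carbonyl)amino really are remains open. Also open, going by these compounds, is how an amine or a carboxylic acid at this place would read in this assay against hydrogen and methoxy.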